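The compounds below may be only part of what the source reports. "The series", "measured", "known", "first", "only" and "open" are said of these compounds alone.

Measured compounds in an ADME assay on NHDF cells (Homo sapiens) for cytotoxicity, read by MTT assay, with a stated time of 72 h; on this read-out lower numbers stand for stronger inhibition and higher numbers for weaker inhibition:
Compound 1, `COc1cccc(/C=C2\CCC/C(=C\c3cccc(Cl)c3)C2=O)c1OC`: 21400 nM
Compound 2, `COc1cccc(/C=C2\CCC/C(=C\c3cccc(OC)c3OC)C2=O)c1`: 16400 nM
Compound 3, `COc1cccc(/C=C2\CCC/C(=C\c3ccc(O)c(Cl)c3)C2=O)c1OC`: 39500 nM

Compound 4, `COc1cc(/C=C2\CCC/C(=C\c3cccc(OC)c3OC)C2=O)ccc1O`, is not yet measured in this assay.

Compound 3 stands at the highest of the three numbers, but only its gap to compound 2, a 2.4-fold higher number from compound 2 to compound 3 (0.38 log units; beyond the scatter), is beyond the scatter; the step of a 1.8-fold higher number from compound 1 to compound 3 (0.27 log units; within the scatter) is within it.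

The change from compound 3 to compound 4, (methoxy in place of chloro on an aromatic carbon), is the same kind of change as methoxy in place of chloro on an aromatic carbon, for which the measured step of a 1.3-fold lower number from compound 1 to compound 2 (0.12 log units; within the scatter) lies within the scatter. The two places are not identical: in compound 3 the carbon bearing the change is ortho to a hydroxy group, which compound 1 lacks. The cores differ by hydroxy in place of hydrogen on an aromatic carbon.

For compound 4 a step of about a 1.3-fold lower number from compound 3 to compound 4 (0.11 log units; within the scatter) is expected in this assay, resting on compound 1 to compound 2 showing a 1.3-fold lower number from compound 1 to compound 2 (0.12 log units; within the scatter). Compound 4 is thus estimated at 31000 nM, with a range of 15000 nM to 65000 nM.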

Compound 4, half-maximal inhibitory concentration: 14300 nM
Beside the measured number, compound 4's estimate is 2.2-fold (0.34 log units) above it, outside the stated range (below it).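

In this assay, methoxy in place of chloro on an aromatic carbon gives a 2.8-fold lower number from compound 3 to compound 4 (0.44 log units; beyond the scatter), yet set beside the same change on the other core, this does not amount to a difference between cores: the same change on two cores in this assay, a 1.3-fold lower number (0.12 log units; within the scatter) from compound 1 to compound 2 and a 2.8-fold lower number (0.44 log units; beyond the scatter) from compound 3 to compound 4, 2.1-fold (0.33 log units) apart, within the scatter of two such steps

Hydroxy in place of hydrogen on an aromatic carbon gives a 1.1-fold lower number from compound 2 to compound 4 (0.06 log units; within the scatter), and it also shows no difference between cores: the same change on two cores in this assay, a 1.8-fold higher number (0.27 log units; within the scatter) from compound 1 to compound 3 and a 1.1-fold lower number (0.06 log units; within the scatter) from compound 2 to compound 4, 2.1-fold (0.33 log units) apart, within the scatter of two such steps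

Within the data shown here, the two changes together give a 1.5-fold lower number from compound 1 to compound 4 (0.18 log units; within the scatter), so these pairs are consistent with carrying each change between the two cores, but with only one pair of steps per change they do not show that the steps are equal.

The compounds shown leave open whether an amine or a carboxylic acid in place of the chloro would follow the same course. They also leave open whether ethoxy would behave as methoxy does.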